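Pyridyl halogen swap on the shared quinolone carboxamide core

The compounds below may be only part of what the source reports. "The series", "measured", "known", "first", "only" and "open" are said of these compounds alone.

Compound 1 `NC(=O)c1cn(-c2ccc(O)cc2)c2cc(-c3ccncc3)ccc2c1=O`, compound 2 `NC(=O)c1cn(-c2ccc(O)c(Cl)c2)c2cc(-c3ccncc3)ccc2c1=O` and compound 3 `NC(=O)c1cn(-c2ccc(O)cc2Cl)c2cc(-c3ccncc3Cl)ccc2c1=O` share one core and have all been measured in an assay on isolated protein for inhibition of Calpain-1 catalytic subunit (Homo sapiens); a lower number here means a stronger inhibitor, a higher number a weaker inhibitor. Compound 1 gives 2000 nM in this assay, compound 2 gives 2000 nM and compound 3 gives 2000 nM. For the measured compounds named here, the one single-point step among them, no change at the digits printed from compound 1 to compound 2 (within the scatter), leaves the reading where it was. Compound 3 therefore stands level with compound 1 and compound 2 at the digits shown, and none of the three can be ordered against the others.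

Compound 4 `NC(=O)c1cn(-c2ccc(O)cc2Cl)c2cc(-c3ccnc(F)c3)ccc2c1=O` differs from compound 3 by 2-fluoropyridin-4-yl in place of 3-chloropyridin-4-yl on an aromatic carbon. Going by the values given here, no measured step touches the pyridyl group itself; the only step at hand, from compound 1 to compound 2, concerns a chloro added on a different aromatic carbon and shows no movement in this assay. Nothing in the series suggests that changing the halogen on the pyridyl ring from chloro to fluoro, and its place on that ring, would move the reading beyond the scatter, so the expected step of no change at the digits printed from compound 3 to compound 4 (within the scatter) is essentially flat. Compound 4 is accordingly expected to give about 2000 nM in this assay, with a range from 1000 nM to 4000 nM.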

Compound 4, half-maximal inhibitory concentration: 30000 nM
Beside the measured number, compound 4's estimate is 15-fold (1.18 log units) below it; measured number above the stated range.
By their numbers in this assay, from the lowest: compounds 1, 2 and 3 (each within the scatter of the next); then compound 4.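

In this assay, for the compounds shown here, this pyridyl position proves sensitive: 2-fluoropyridin-4-yl in place of 3-chloropyridin-4-yl gives a 15-fold higher number from compound 3 to compound 4 (1.18 log units; beyond the scatter), whereas the only earlier step, a chloro in place of hydrogen at a different aromatic carbon, gave no change at the digits printed from compound 1 to compound 2 (within the scatter). The groups that leave and enter match in heavy-atom count, hydrogen-bond donors, hydrogen-bond acceptors and net charge, so none of these counted features separates them, yet the reading still moves by a large step; the difference lies in the identity of the halogen and its place on the pyridyl ring, and this single change alters both at once. No supporting evidence is available to explain the step.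

On these data alone, what stays open is whether the step follows the halogen or its place on the ring; 2-chloropyridin-4-yl and 3-fluoropyridin-4-yl on the same core would separate the two. Also open, as far as these compounds go, is how an amine or a methoxy group on the pyridyl ring would read against compound 3 at 2000 nM.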